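Taking one hydroxy group off compound 3

The source may hold more compounds than are shown below. What is called first, only, known or untested is meant among the compounds shown, and "the series" means these compounds.

For the measured compounds named here, in a functional assay on HeLa cells (Homo sapiens) for inhibition, read by trypan blue exclusion, with a stated time of 72 h (on this read-out lower numbers stand for stronger inhibition of growth and higher numbers for weaker inhibition of growth), compound 3 `Cc1c(-c2ccc(O)c(O)c2)n(CCCOc2ccccc2)c2ccc(O)cc12` gives 18000 nM as the highest of the three numbers so far. Compound 4 `Cc1c(-c2ccc(O)cc2)n(CCCOc2ccccc2)c2ccc(O)cc12` is still unmeasured. The change hydrogen in place of hydroxy on an aromatic carbon puts hydrogen in place of hydroxy on an aromatic carbon and turns 3,4-dihydroxyphenyl into 4-hydroxyphenyl. Going by the values given here, no measured step makes this change. Among the compounds with values here, the one measured step of a 2.0-fold lower number from compound 1 to compound 2 (0.30 log units; within the scatter) lies in the chain on the aromatic nitrogen instead. Still, compound 1 `CCCn1c(-c2ccc(O)cc2)c(C)c2cc(O)ccc21` at 7900 nM and compound 2 `Cc1c(-c2ccc(O)cc2)n(CCCCOc2ccccc2)c2ccc(O)cc12` at 4000 nM both carry the 4-hydroxyphenyl of compound 4. A step beyond the scatter toward a lower number is therefore expected in this assay for this pair. The estimate is a 3.3-fold lower number from compound 3 to compound 4 (0.51 log units; beyond the scatter) for this change. For compound 4 the expected value is 5500 nM with a range from 2200 nM to 13000 nM as estimated.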

Compound 4, concentration for 50% growth inhibition: 4400 nM
Compound 4: the middle estimate sits 1.3-fold (0.10 log units) above what was measured; low and high end bracket the measured number.
By their numbers in this assay, from the lowest: compounds 2, 4 and 1 (each within the scatter of the next); then compound 3.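

In this assay, for the compounds shown here, taking off the hydroxy group gives a 4.1-fold lower number from compound 3 to compound 4 (0.61 log units; beyond the scatter) as the first measured change at this aromatic carbon. Changing only the chain on the aromatic nitrogen gives a 1.1-fold higher number from compound 2 to compound 4 (0.04 log units; within the scatter) and a 1.8-fold lower number from compound 1 to compound 4 (0.25 log units; within the scatter) for the other two new pairs. Of these three steps, only the change from 3,4-dihydroxyphenyl to 4-hydroxyphenyl goes beyond the scatter.

No measurement here explains this step. Going by these compounds, how a methoxy group or a fluorine atom at this aromatic carbon, or an amine at the end of the chain, would read remains open.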